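The compounds below may be only part of what the source reports. "The series", "measured", "known", "first", "only" and "open" are said of these compounds alone.

Compound 1 `CS(=O)(=O)N(CC(=O)Nc1ccc(F)cn1)c1ccccc1Cl` and compound 2 `CS(=O)(=O)N(CC(=O)Nc1cccnc1F)c1ccccc1Cl` share a core and differ only in the group on the amide-type nitrogen. In a functional assay on HEK293 cells for positive allosteric modulation of metabotropic glutamate receptor 5 (Homo sapiens), read by fluorescence and calcium flux (on this read-out lower numbers stand for smaller maximal responses and higher numbers for larger maximal responses), compound 1 is recorded as "not determined" (no result reported), so no number exists for it. In this assay, going by the values given here, compound 2 gives 42%, the only number available here, with one further entry lacking a figure. Compound 3 `CS(=O)(=O)N(CC(=O)Nc1ccc(F)nc1)c1ccccc1Cl` carries 6-fluoropyridin-3-yl in place of 2-fluoropyridin-3-yl on an amide-type nitrogen. Among the compounds with values here, no step between measured compounds exists, so the effect of this change is unknown; it is expected to stay within the scatter, with no clear direction. Compound 3 is therefore estimated at 45% in this assay, between 20% and 75%, an expected step of a number 3 percentage points higher from compound 2 to compound 3 (within the scatter).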

Compound 3, largest response reached (Emax), in percent of the reference or control that the assay uses: 35%
Beside the measured number, compound 3's estimate is 10 percentage points above it; the range from low to high includes it.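

Going by these compounds alone, exchanging 2-fluoropyridin-3-yl for 6-fluoropyridin-3-yl on the amide-type nitrogen gives the first readable step at this position in this assay with a number 7 percentage points lower from compound 2 to compound 3 (within the scatter) and so shows that this rearrangement of the same atoms does not move the maximal response beyond the scatter. Nothing available here accounts for the result. Compound 1 supplies no number, so its 5-fluoropyridin-2-yl group remains unplaced in this series. Also open, on these data alone, is how an unsubstituted pyridin-3-yl, a chloropyridin-3-yl or a phenyl group on that nitrogen would read.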